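The compounds below may be only part of what the source reports. "The series", "measured", "known", "first", "only" and "open" are said of these compounds alone.

Three compounds sharing one core have been examined. Compound 1 `COc1ccc(C2CC(=NOC(=O)c3ccccc3)CC(c3ccc(OC)cc3)N2C)cc1` carries an unsubstituted phenyl on the carbonyl carbon of the ester, compound 2 `COc1ccc(C2CC(=NOC(=O)c3ccc(Br)cc3)CC(c3ccc(OC)cc3)N2C)cc1` a 4-bromophenyl, and compound 3 `COc1ccc(C2CC(=NOC(=O)c3cccc(Cl)c3)CC(c3ccc(OC)cc3)N2C)cc1` a 3-chlorophenyl. In a functional assay, with a stated time of 30 min (a higher number here means a weaker inhibitor, a lower number a stronger inhibitor), compound 1 gives 375000 nM, compound 2 gives 121000 nM, and compound 3 gives 136000 nM. The two halogen introductions gave a 3.1-fold lower number from compound 1 to compound 2 (0.49 log units; beyond the scatter) and a 2.8-fold lower number from compound 1 to compound 3 (0.44 log units; beyond the scatter), while the exchange of one halophenyl for the other gave a 1.1-fold higher number from compound 2 to compound 3 (0.05 log units; within the scatter), so compound 3 stands with compound 2 at the lower numbers of this small set, apart from compound 1.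

Compound 4 `COc1ccc(C2CC(=NOC(=O)c3ccccc3O)CC(c3ccc(OC)cc3)N2C)cc1` is not yet measured. The change is 2-hydroxyphenyl in place of 3-chlorophenyl on a carbonyl carbon. Among the measured compounds shown here, no measured step involves a hydroxy group; the only steps that bear on it are those removing or moving a halogen, which were modest. The chloro gain is therefore assumed lost and a number nearer to compound 1 is expected, a step of about a 1.8-fold higher number from compound 3 to compound 4 (0.26 log units; within the scatter) in this assay. Compound 4 is estimated at 250000 nM, expected to fall between 80000 nM and 700000 nM.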

Compound 4, half-maximal inhibitory concentration: 29000 nM
The estimate for compound 4 lay 8.6-fold (0.94 log units) above the measured number; measured number outside the range, below it.
By their numbers in this assay, from the lowest: compound 4; then compounds 2 and 3 (each within the scatter of the next); then compound 1.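

In this assay, among the compounds shown here, the aryl group on the carbonyl carbon tolerates a larger change than the halogen compounds showed: adding the hydroxy group gave a 13-fold lower number from compound 1 to compound 4 (1.11 log units; beyond the scatter) and this is the only large step in the set. For the compounds shown here, the 2-hydroxyphenyl group also goes beyond both halophenyl groups, with a 4.7-fold lower number from compound 3 to compound 4 (0.67 log units; beyond the scatter) and a 4.2-fold lower number from compound 2 to compound 4 (0.62 log units; beyond the scatter) so the lowest number at this position so far belongs to the one group here that carries a hydrogen-bond donor and acceptor. Nothing available explains why this group gives such a step.

Going by these compounds, the hydroxy group appears only within the 2-hydroxyphenyl group, so whether another placing on the ring would give a similar step remains open. On these data alone, whether a methoxy group, an amine or a carboxylic acid could match it is also open.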